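Adding a Methoxy Group to the Oxime Aryl of Compound 2

A few compounds are considered here, and "the series" means these few. Any claim that something is new, unique, unknown or untested is made for them only; others in the source may bear on it.

Compound 1, `CCOc1ccc(C(=O)/C=C/c2ccc(F)cc2)cc1`: 53 nM
Compound 2, `COc1ccc(C(=O)/C=C/c2ccc(O/N=C(\C)c3ccccc3)cc2)cc1`: > 200 nM
Compound 3, `CC/C(C)=N/Oc1ccc(/C=C/C(=O)c2ccc(F)cc2)cc1`: 28 nM

Of the compounds shown here, three have been measured in an assay on isolated protein for inhibition of Amine oxidase [flavin-containing] B (Homo sapiens); on this read-out higher numbers stand for weaker inhibition and lower numbers for stronger inhibition. Compound 1 gives 53 nM and compound 3 gives 28 nM; these two values lie within the usual scatter of each other. For compound 2 the assay reports no number but only a limit, > 200 nM. Compound 2 therefore stands at the limit of > 200 nM in this assay, at which 1 of the 3 values shown sits, the weakest end of what has been seen so far, and how far beyond that limit it lies is not known.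

Compound 4, `COc1ccc(C(=O)/C=C/c2ccc(O/N=C(\C)c3ccc(OC)cc3)cc2)cc1`, has not yet been measured. It differs from compound 2 in one place: methoxy in place of hydrogen on an aromatic carbon. Among the measured compounds shown here, no pair of measured compounds shows what this particular change does, so the expectation rests on compound 2 alone. Since compound 2 already sits at the limit, compound 4 is expected to remain weak, with a fair chance that this assay again returns only a limit. Compound 4 is therefore expected at 500 nM, with a range from 150 nM to 2000 nM. The step that the limit leaves unreadable from compound 2 to compound 4 implied by this estimate is expected to be small and uncertain in direction.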

Compound 4, half-maximal inhibitory concentration: > 200 nM
Compound 4: a limit, no number; the forecaster's own chance of this, stated with the estimate: 60%; the middle value lies beyond the limit too.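

Compound 2 and compound 4 both return only a limit in this assay, not a number, so no step between them can be read: the limit of > 200 nM in this assay, at which 2 of the 4 values shown sit.

The compounds shown leave open how far beyond that limit each of the two lies, and whether phenyl to 4-methoxyphenyl changes inhibition at all.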